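The source may hold more compounds than are shown below. What is called first, only, known or untested is meant among the compounds shown, and "the series" means these compounds.

Series in a functional assay on A-431 cells (Homo sapiens) for antiproliferative activity, read by MTT assay, with a stated time of 72 h; a lower number here means a stronger inhibitor, a higher number a weaker inhibitor:
- compound 1 `CN1CCN(c2ccc(Nc3ncc4nc(Nc5ccc(F)cc5)n([C@H]5CCCN(S(=O)(=O)C6CC6)C5)c4n3)cc2)CC1`: 1340 nM
- compound 2 `CN1CCN(c2ccc(Nc3ncc4nc(Nc5ccccc5)n([C@@H]5CCNC5)c4n3)cc2)CC1`: "not determined" (no result reported)
- compound 3 `CN1CCN(c2ccc(Nc3ncc4nc(Nc5ccc(F)cc5)n([C@H]5CCNC5)c4n3)cc2)CC1`: "not determined" (no result reported)

Compound 2 has no number and so no place on the scale. Among the compounds with values here, the same holds for compound 3, which leaves a single measured value and no measured step.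

Next up is compound 4 `CN1CCN(c2ccc(Nc3ncc4nc(Nc5ccccc5)n([C@@H]5CCN(S(=O)(=O)C6CC6)C5)c4n3)cc2)CC1`, which is still to be measured. The structural change is cyclopropylsulfonyl in place of hydrogen on an amine nitrogen in a ring. The size of this step in this assay cannot be read from the data, as there is no value for compound 2 to start from. A moderate step towards weaker inhibition is expected, though this is a tentative call. Within the data shown here, the only anchor is compound 1, which also carries a cyclopropylsulfonyl group and gives 1340 nM. A value in the same region is therefore expected for the new compound, with a wide margin.

The estimated value for compound 4 is 1200 nM, with an expected range of 300 nM to 5000 nM.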

Compound 4, half-maximal inhibitory concentration: > 10000 nM
Compound 4: no number, only a limit (the forecaster's own chance of this, stated with the estimate: 7%); middle value at least 8.3-fold (0.92 log units) away from the limit.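

In this assay compound 4 gives > 10000 nM, which is a limit of the assay and not a number. Compound 2 carries no number, so no step can be read between compound 2 and compound 4. The compounds shown leave open how far cyclopropylsulfonyl in place of hydrogen on an amine nitrogen in a ring shifts the result in this assay.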